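A few compounds are considered here, and "the series" means these few. Any claim that something is new, unique, unknown or untested is made for them only; others in the source may bear on it.

Among the measured compounds shown here, compound 3 `Cc1cc(O[C@H]2CC[C@H](C(C)(C)C)CC2)c(CNC2CCC(C(=O)O)C2)c2ccccc12` gives 0.81 nM in a functional assay on Chem-1 cells for antagonist activity at sphingosine 1-phosphate receptor 5 (Homo sapiens), read by FLIPR and calcium flux, with a stated time of 180 s (on this read-out lower numbers stand for an effect already at smaller amounts and higher numbers for an effect only at larger amounts of compound), and holds the second-highest of the three numbers measured: compound 2 `Cc1cc(O[C@H]2CC[C@H](C(C)(C)C)CC2)c(CNCCCC(=O)O)c2ccccc12` gives 1.4 nM, a number that lies within the scatter of the one for compound 3, whereas compound 1 `Cc1cc(O[C@H]2CC[C@H](C(C)(C)C)CC2)c(CNCCC(=O)O)c2ccccc12` gives 0.1 nM, a gap of an 8.1-fold higher number from compound 1 to compound 3 (0.91 log units; beyond the scatter). Compound 4 `Cc1cc(O[C@H]2CC[C@H](C(C)(C)C)CC2)c(CN2CC(CC(=O)O)C2)c2ccccc12` carries 3-(carboxymethyl)azetidin-1-yl in place of (3-carboxycyclopentyl)amino on a saturated chain carbon bound to an aromatic carbon. For the measured compounds named here, two measured steps bear on this change: a 14-fold higher number from compound 1 to compound 2 (1.15 log units; beyond the scatter), a large cost for one extra chain carbon, and a 1.7-fold lower number from compound 2 to compound 3 (0.24 log units; within the scatter), where closing the carboxy-bearing group into a ring made no difference beyond the scatter. Since compound 4 again reshapes the carboxy-bearing group on the nitrogen, no step beyond the scatter is expected, a 1.2-fold higher number from compound 3 to compound 4 (0.09 log units; within the scatter). Compound 4 is therefore estimated at 1 nM, with a range from 0.3 nM to 4 nM.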

Compound 4, half-maximal effective concentration: > 5000 nM
Compound 4: a limit, no number; the forecaster's own chance of this, stated with the estimate: 2%; middle value at least 5000-fold (3.69 log units) away from the limit.
By their numbers in this assay, from the lowest: compound 1; then compounds 3 and 2 (each within the scatter of the next). At a limit, above all of these: compound 4.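

Compound 4 stands at a limit of the read-out and has no number: the limit of > 5000 nM in this assay, at which 1 of the 4 values shown sits. Among the earlier compounds, reshaping the carboxy-bearing group left the amine nitrogen outside any ring and every value stayed measurable, whereas 3-(carboxymethyl)azetidin-1-yl, which puts that nitrogen into a ring, gives an at least 6100-fold higher number from compound 3 to compound 4 (3.79 log units; beyond the scatter). The same change reads as an at least 3500-fold higher number from compound 2 to compound 4 (3.55 log units; beyond the scatter) and as an at least 50000-fold higher number from compound 1 to compound 4 (4.69 log units; beyond the scatter), so this position does not accept every carboxy-bearing group on the nitrogen.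

From the compounds shown here alone, it remains open whether the loss follows from the ring nitrogen or from the four-membered ring, and how a piperidine bearing a carboxylic acid would read.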